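Adding methoxy to compound 2: a small step expected

A few compounds are considered here, and "the series" means these few. Any claim that something is new, unique, unknown or untested is made for them only; others in the source may bear on it.

Measured in a functional assay on DLD-1 cells (Homo sapiens) for cytotoxicity, with a stated time of 48 h; a higher number here means a weaker inhibitor, a lower number a stronger inhibitor:
Compound 1 `CCCCCOc1ccc2oc(/C=C/[S+](C)[O-])cc(=O)c2c1`: 6600 nM
Compound 2 `C[S+]([O-])/C=C/c1cc(=O)c2ccccc2o1`: 8000 nM
Compound 3 `CC(C)CCOc1ccc2oc(/C=C/[S+](C)[O-])cc(=O)c2c1`: 4100 nM

Compound 2 does not separate clearly from its two neighbours on these numbers. Both a 1.2-fold higher number from compound 1 to compound 2 (0.08 log units; within the scatter) and a 2.0-fold lower number from compound 2 to compound 3 (0.29 log units; within the scatter) stay within the usual scatter, so the three compounds cannot be ranked.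

Compound 4 `COc1cccc2c(=O)cc(/C=C/[S+](C)[O-])oc12` has not been measured yet. It differs from compound 2 by methoxy in place of hydrogen on an aromatic carbon, with methoxy in place of hydrogen on an aromatic carbon, ortho to a fused ring and meta to a fused ring.

The closest evidence comes from the two steps that exchange hydrogen and a longer chain on an aromatic carbon. Taking away pentyloxy gave a 1.2-fold higher number from compound 1 to compound 2 (0.08 log units; within the scatter), and adding isopentyloxy gave a 2.0-fold lower number from compound 2 to compound 3 (0.29 log units; within the scatter). Neither step went beyond the scatter. Among the compounds with values here, this guide is weak, as those chains sit on a different aromatic carbon and no measured compound carries methoxy.

No step beyond the scatter is therefore expected in this assay, and the direction is uncertain. The estimated step is a 1.2-fold lower number from compound 2 to compound 4 (0.09 log units; within the scatter). For compound 4 the expected value is 6500 nM, within an estimated range of 3000 nM to 14000 nM.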

Compound 4, half-maximal inhibitory concentration: 9000 nM
The estimate for compound 4 lay 1.4-fold (0.14 log units) below the measured number; low and high end bracket the measured number.
By their numbers in this assay, from the lowest: compounds 3, 1, 2 and 4 (each within the scatter of the next, the first and the last beyond it).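

Methoxy in place of hydrogen on an aromatic carbon, ortho to a fused ring and meta to a fused ring, gives a 1.1-fold higher number from compound 2 to compound 4 (0.05 log units; within the scatter) in this assay and so adds a new position and a new group to the picture without a step that can be told apart from the usual scatter. The earlier substituted compounds, compound 1 and compound 3, carry pentyloxy and isopentyloxy on a different aromatic carbon, so compound 4 extends the finding of no clear step to this second position, here with a group of only 2 heavy atoms and 1 hydrogen-bond acceptor. Nothing shown here offers an explanation for this result.

As far as these compounds go, it remains open whether a longer chain, an amine or a carboxylic acid on this same carbon would give a step beyond the scatter. Also open, from the compounds shown here alone, is how methoxy would compare with pentyloxy and isopentyloxy on the carbon that carries those chains in compound 1 and compound 3.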